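The source may report more compounds than this note shows. Statements on the series, on what has been measured and on what is new or still open speak of the compounds shown alone.

Measured so far in a functional assay on MCF7 cells (Homo sapiens) for inhibition, read by MTT assay; a lower number here means a stronger inhibitor of growth, a higher number a weaker inhibitor of growth:
- compound 1 `CC1=C(/C=C/C(C)=C/C=C/C(C)=C\C(=O)Nc2ccccc2)C(C)(C)CCC1n1ccnc1`: 1900 nM
- compound 2 `CC1=C(/C=C/C(C)=C/C=C/C(C)=C\C(=O)Nc2cccc(F)c2)C(C)(C)CCC1n1ccnc1`: 5490 nM
- compound 3 `CC1=C(/C=C/C(C)=C/C=C/C(C)=C\C(=O)NCc2ccc(O)cc2)C(C)(C)CCC1n1ccnc1`: 160 nM

Compound 3 has the lowest number of the three, and its steps to both others are beyond the scatter. Compound 4 `CC1=C(/C=C/C(C)=C/C=C/C(C)=C\C(=O)Nc2ccccc2O)C(C)(C)CCC1n1ccnc1` has 2-hydroxyphenyl in place of 4-hydroxybenzyl on an amide-type nitrogen. Within the data shown here, no measured step makes this exact change. The nearest evidence is two large steps to a lower number: a 12-fold lower number from compound 1 to compound 3 (1.07 log units; beyond the scatter) and a 34-fold lower number from compound 2 to compound 3 (1.54 log units; beyond the scatter). Compound 4 again carries a phenyl ring on that nitrogen, like compound 1 and compound 2, but with a hydroxy group that they lack. Partial loss of those gains is therefore expected, with an estimated 5.6-fold higher number from compound 3 to compound 4 (0.75 log units; beyond the scatter). Compound 4 is expected at 900 nM, within an estimated range of 250 nM to 3500 nM.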

Compound 4, concentration for 50% growth inhibition: 1090 nM
The estimate for compound 4 lay 1.2-fold (0.08 log units) below the measured number; measured number inside the range.
By their numbers in this assay, from the lowest: compound 3; then compounds 4 and 1 (each within the scatter of the next); then compound 2.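

A hydroxy group on the phenyl ring does not recover the low number of the 4-hydroxybenzyl group in this assay (a 6.8-fold higher number from compound 3 to compound 4 (0.83 log units; beyond the scatter)). Against the plain phenyl of compound 1, the 2-hydroxyphenyl group makes no clear difference (a 1.7-fold lower number from compound 1 to compound 4 (0.24 log units; within the scatter)), though it does stand apart from 3-fluorophenyl (a 5.0-fold lower number from compound 2 to compound 4 (0.70 log units; beyond the scatter)). Nothing available explains these differences.

The compounds shown leave open whether the low number of compound 3 goes with the benzyl part or with its hydroxy group. A plain benzyl group on that nitrogen would help separate the two.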